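Dropping One Methoxy From the Most Potent Compound

The source may report more compounds than this note shows. Statements on the series, on what has been measured and on what is new or still open speak of the compounds shown alone.

Compound 2 `C=C(Br)C(=O)Nc1cccc(-c2cn3nc(-c4ccc(OC)c(OC)c4)sc3n2)c1` holds the strongest position among the three compounds measured in a functional assay on CCRF-CEM cells (Homo sapiens) for inhibition, read by cell counting, with a stated time of 3 days (a higher number here means a weaker inhibitor, a lower number a stronger inhibitor), where compound 2 gives 380 nM. For the measured compounds named here, the nearest measured compound is compound 1 `COc1ccc(-c2nn3cc(-c4cccc(N)c4)nc3s2)cc1OC`, which in this assay gives 14000 nM; the step of a 37-fold lower number from compound 1 to compound 2 (1.57 log units; beyond the scatter) is the only measured change at a single place. Compound 3 `CCc1ccc(-c2nn3cc(-c4cccc(N)c4)nc3s2)cc1` gives 22000 nM in this assay, the highest number of the three.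

Compound 4 `C=C(Br)C(=O)Nc1cccc(-c2cn3nc(-c4ccc(OC)cc4)sc3n2)c1` differs from compound 2 in one place: hydrogen in place of methoxy on an aromatic carbon. Cut one bond further out, the change reads 3,4-dimethoxyphenyl to 4-methoxyphenyl.

Going by the values given here, no measured step removes a methoxy group. Among the compounds with values here, the one measured step, from compound 1 to compound 2, changes a different part of the molecule and does not speak to this edit. Compound 1 and compound 3 differ in that same outer ring but not at a single place, and their values lie close together, which hints that changes on this ring move the number little. A step of modest size is therefore expected, if anything toward a slightly higher number, and the estimated step is a 1.6-fold higher number from compound 2 to compound 4 (0.20 log units; within the scatter). Compound 4 is expected to give about 600 nM, most likely between 250 nM and 1500 nM.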

Compound 4, half-maximal inhibitory concentration: 1200 nM
Beside the measured number, compound 4's estimate is 2.0-fold (0.30 log units) below it, within the range that was stated.
By their numbers in this assay, from the lowest: compound 2; then compound 4; then compounds 1 and 3 (each within the scatter of the next).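

For the compounds shown here, on the outer ring, going from 3,4-dimethoxyphenyl to 4-methoxyphenyl in this assay gives a 3.2-fold higher number from compound 2 to compound 4 (0.50 log units; beyond the scatter), and this is the first change on that ring that can be read at a single place. It shows that this ring carbon is not a silent spot: with everything else held the same, including the (1-bromoethenyl)carbonyl on the nitrogen, the methoxy group goes with a lower number than hydrogen does, something compound 1 and compound 3 could not show, as they differ in more than one place. Nothing at hand explains why the number moves with this change.

On these data alone, whether a hydroxy group, a fluorine or an ethoxy group on this carbon would land nearer to compound 2 or to compound 4 stays open, so only methoxy against hydrogen can be read here. Also open, as far as these compounds go, is whether removing the same methoxy group would shift the number by a similar amount in a compound with the free amine, such as compound 1, in place of the (1-bromoethenyl)carbonyl.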